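The source may report more compounds than this note shows. Statements on the series, on what has been measured and on what is new or still open speak of the compounds shown alone.

Of the compounds shown here, three have been measured in an assay on L cells for inhibition of Protein-serine O-palmitoleoyltransferase porcupine (Mus musculus), read by reporter gene assay, with a stated time of 24 h; on this read-out lower numbers stand for an effect already at smaller amounts and higher numbers for an effect only at larger amounts of compound. Compound 1 `COc1ccc2nc(NC(=O)CNC(=O)c3nn(-c4ccccc4)c(=O)c4ccccc34)sc2c1` gives 210 nM in this assay. Compound 3 `O=C(CNC(=O)c1nn(-c2ccccc2)c(=O)c2ccccc12)Nc1nc2ccc(C(F)(F)F)cc2s1` gives 110 nM. Compound 2 `COc1ccc(-n2c(SCC(=O)Nc3nc4ccc(C(F)(F)F)cc4s3)nc3c(c2=O)SCC3)cc1` gives 100 nM, and the difference between its core and the core of compound 3 is not broken down here; the two values lie within the scatter of each other. Compound 3 and compound 1 differ in one place only: methoxy in place of trifluoromethyl on an aromatic carbon. That change produced a 1.9-fold higher number from compound 3 to compound 1 (0.28 log units; within the scatter).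

Compound 4 `COc1ccc(-n2c(SCC(=O)Nc3nc4ccc(OC)cc4s3)nc3c(c2=O)SCC3)cc1` has not yet been measured in this assay. It arises from compound 2 by the same change as the one just described: methoxy in place of trifluoromethyl on an aromatic carbon. The change has appeared only once with a measured outcome, and there it stayed within the scatter. Compound 4 is therefore expected to sit close to compound 2, with a step of a 1.9-fold higher number from compound 2 to compound 4 (0.28 log units; within the scatter). Among the compounds with values here, this expectation rests on the single earlier step of a 1.9-fold higher number from compound 3 to compound 1 (0.28 log units; within the scatter). Compound 4 is estimated to give 190 nM, with a likely range from 100 nM to 360 nM.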

Compound 4, half-maximal effective concentration: 120 nM
Compound 4: middle estimate off by 1.6-fold (0.20 log units), on the high side; measured number inside the range.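

In this assay, methoxy in place of trifluoromethyl on an aromatic carbon gave a 1.2-fold higher number from compound 2 to compound 4 (0.08 log units; within the scatter) on the second core. Set beside the earlier case, the two steps do not differ: the same change on two cores in this assay, a 1.9-fold higher number (0.28 log units; within the scatter) from compound 3 to compound 1 and a 1.2-fold higher number (0.08 log units; within the scatter) from compound 2 to compound 4, 1.6-fold (0.20 log units) apart, within the scatter of two such steps. On these two cores, then, the change carried over with the same outcome, staying within the scatter both times, but that does not show that the change has a real effect of its own on the read-out, and two cores cannot show that the same would hold on a third.

Every step shown exchanges only these two groups, so what an amine, a carboxylic acid or a longer alkoxy chain would do on that aromatic carbon remains open. As far as these compounds go, it also remains open whether the cores would still behave alike with such a group, where a step might be large enough to stand clear of the scatter and allow a real comparison between them.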